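Methyl to Chloro on the Amide-Side Ring: Maximal Response

This account rests on a few compounds, and the source may have more. Where it says the series, first, only, none or still open, it means among the compounds named here.

Measured compounds:
compound 1 `COc1ccc(NS(=O)(=O)c2ccc(NC(=O)c3ccc(Cl)cc3Cl)cc2)cc1` — "not determined" (no result reported)
compound 2 `Cc1cc(Cl)ccc1C(=O)Nc1ccc(S(=O)(=O)Nc2ccccc2)cc1` — 123%
compound 3 `O=C(Nc1ccc(Cl)cc1Cl)c1ccc(S(=O)(=O)Nc2ccccc2)cc1` — "not determined" (no result reported)

Three compounds share the core of compound 2, and only one of them carries a number. In a functional assay on HEK293 cells for agonist activity at probable G-protein coupled receptor 27 (Homo sapiens), read by a luciferase reporter and beta-arrestin recruitment, with a stated time of 10 min (a higher number here means a larger maximal response, a lower number a smaller maximal response), compound 2 gives 123%. Among the compounds with values here, compound 1 has no result in this assay, and compound 3 likewise has no result, so compound 2 stands alone: it is the only entry with a value, and there is no measured neighbour against which its maximal response can be set.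

Compound 4 `O=C(Nc1ccc(S(=O)(=O)Nc2ccccc2)cc1)c1ccc(Cl)cc1Cl` is the next compound. It differs from compound 2 in one place: chloro in place of methyl on an aromatic carbon. The exchange sits on the ring that bears the chloro group already present in compound 2, ortho to a large group and meta to that chloro group.

Within the data shown here, with no step between measured compounds to draw on, there is no basis for expecting a shift beyond the scatter in either direction. The maximal response of compound 4 is therefore expected to stay close to that of compound 2, and the estimated step of a number 8 percentage points lower from compound 2 to compound 4 (within the scatter) is taken as none beyond the scatter. Compound 4 is estimated at 115%, within a range from 85% to 140%.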

Compound 4, largest response reached (Emax), in percent of the reference or control that the assay uses: 100%
For compound 4 the middle estimate is 15 percentage points above the measured one; low and high end bracket the measured number.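

Within the data shown here, the exchange of methyl for chloro on this aromatic carbon, ortho to a large group and meta to a chloro group, gives the first step that can be read in this assay: a number 23 percentage points lower from compound 2 to compound 4 (beyond the scatter). This shows that the position is not indifferent to the change: one heavy atom replaces one heavy atom, no hydrogen-bond donor or acceptor enters or leaves, and yet the maximal response moves, with compound 4 giving 100%. No measurement offered here explains the step, which rests on this single pair of compounds.

On these data alone, whether a fluoro group, a trifluoromethyl group or a nitrile on the same carbon would give a response closer to compound 2 or to compound 4 remains open, as does the outcome with an amine or a carboxylic acid there. Among these compounds, compound 1 and compound 3 carry no number, so no step to either can be read, and it remains unknown whether the same exchange would have a similar effect with a different group elsewhere on the shared core.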